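Aminoflavone series: core methoxy addition, THP-1 cytotoxicity

This account rests on a few compounds, and the source may have more. Where it says the series, first, only, none or still open, it means among the compounds named here.

Measured so far:
compound 1, `COc1ccc(-c2cc(=O)c3cc(N)ccc3o2)cc1`: 124000 nM
compound 2, `Nc1ccc2oc(-c3ccc(F)cc3)cc(=O)c2c1`: 10000 nM

Among the compounds with values here, in an ADME assay on THP-1 cells (Homo sapiens) for cytotoxicity, read by flow cytometry and propidium iodide staining, with a stated time of 72 h (on this read-out lower numbers stand for stronger inhibition and higher numbers for weaker inhibition), compound 1 stands at the higher of the two numbers; the only neighbour is compound 2, reached by a 12-fold lower number from compound 1 to compound 2 (1.09 log units; beyond the scatter) through fluoro in place of methoxy on an aromatic carbon of the pendant ring.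

Compound 3, `COc1ccc(-c2oc3ccc(N)cc3c(=O)c2OC)cc1`, is not yet measured. Its change from compound 1 is methoxy in place of hydrogen on an aromatic carbon. Within the data shown here, this change sits on the shared core, not on the pendant ring, and no measured step touches that position; the one step known, the large one from compound 1 to compound 2, concerns a different group at a different place and gives no guidance here. With nothing in the series bearing on the change, the expectation for compound 3 is a number close to that of compound 1, with a 1.0-fold lower number from compound 1 to compound 3 (0.01 log units; within the scatter) not beyond the scatter. The estimate for compound 3 in this assay is 120000 nM, within 40000 nM to 300000 nM.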

Compound 3, half-maximal inhibitory concentration: 21000 nM
Beside the measured number, compound 3's estimate is 5.7-fold (0.76 log units) above it, and the stated range ends above it.
By their numbers in this assay, from the lowest: compound 2; then compound 3; then compound 1.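

In this assay, the shared core responds at this position: methoxy in place of hydrogen on an aromatic carbon, two atoms from the ring oxygen, gives a 5.9-fold lower number from compound 1 to compound 3 (0.77 log units; beyond the scatter), a modest step beyond the scatter. The earlier step, a 12-fold lower number from compound 1 to compound 2 (1.09 log units; beyond the scatter), concerned only the pendant ring, so the number is now shown to move with a change on the core as well, though by less in this single comparison. Nothing measured on these compounds accounts for the step.

Going by these compounds, whether the lower number is specific to methoxy remains open, and a hydroxyl group, a chlorine atom or an ethoxy group at the same carbon would test this. Also open, on these data alone, is whether the same core change lowers the number when fluoro replaces methoxy on the pendant ring, as in compound 2.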